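A few compounds are considered here, and "the series" means these few. Any claim that something is new, unique, unknown or untested is made for them only; others in the source may bear on it.

Compound 1 `CCCCCCCCCCc1ccc(-c2noc(CCCCN)n2)cc1`: 55%
Compound 2 `CCCCCCCCCCc1ccc(-c2noc([C@@H]3CCNC3)n2)cc1`: 62%

Both compounds were measured in an assay on HeLa cells for inhibition of sphingosine-1-phosphate transporter SPNS2 (Mus musculus), read by LC-MS, tested at 2 uM; on this read-out higher numbers stand for more inhibition at the one concentration tested (going by the name of the read-out) and lower numbers for less inhibition. Going by the values given here, compound 2 stands alongside compound 1, the two numbers lying within the scatter of each other, and the one measured step, a number 7 percentage points higher from compound 1 to compound 2 (within the scatter), did not rise above that scatter. Compound 3 `CCCCCCCCCCc1ccc(-c2noc([C@H]3CCCN3)n2)cc1` differs from compound 2 by pyrrolidin-2-yl in place of pyrrolidin-3-yl on an aromatic carbon. Among the compounds with values here, no measured pair shows this exact change, so the only guide is that earlier step, which stayed within the scatter. Compound 3 is therefore expected to give about 58% in this assay, somewhere between 40% and 76%, with the expected step of a number 4 percentage points lower from compound 2 to compound 3 (within the scatter) staying within the scatter.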

Compound 3, a percentage reported as inhibition, at one concentration (the size of the read-out at that concentration, not a potency): 12%
Compound 3: middle estimate off by 46 percentage points, on the high side, outside the stated range (below it).
By their numbers in this assay, from the lowest: compound 3; then compounds 1 and 2 (each within the scatter of the next).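

Swapping pyrrolidin-3-yl for pyrrolidin-2-yl, which uses the same atoms joined differently, brings a number 50 percentage points lower from compound 2 to compound 3 (beyond the scatter) in this assay and shows that this position on the shared core is far less forgiving than the earlier pair suggested. Replacing 4-aminobutyl with pyrrolidin-2-yl likewise brings a number 43 percentage points lower from compound 1 to compound 3 (beyond the scatter) here, so carrying a ring nitrogen at this position does not by itself hold the inhibition; how the group is joined to the core matters. Still open, on these data alone, is whether the opposite stereocentre of pyrrolidin-2-yl, or a piperidin-3-yl ring, would stay with compound 2 or fall with compound 3. Nothing measured here explains the drop.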